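Methyl in place of a ring hydrogen: compound 3 expected

The source may hold more compounds than are shown below. What is called first, only, known or untested is meant among the compounds shown, and "the series" means these compounds.

Measured so far:
- compound 1 `O=C(Nc1ccc(Oc2ccnc3[nH]ccc23)cc1)c1nn(-c2ccc(Br)cc2)ccc1=O` — 6240 nM
- compound 2 `O=C(Nc1ccc(Oc2ccnc3[nH]ccc23)cc1)c1nn(-c2ccc(Br)cc2F)ccc1=O` — 26100 nM

In a functional assay on A549 cells (Homo sapiens) for cytotoxicity, read by MTT assay, with a stated time of 72 h (a higher number here means a weaker inhibitor, a lower number a stronger inhibitor), compound 2 stands highest of the two numbers; its nearest neighbour is compound 1, and a 4.2-fold higher number from compound 1 to compound 2 (0.62 log units; beyond the scatter). Compound 3 `Cn1ccc2c(Oc3ccc(NC(=O)c4nn(-c5ccc(Br)cc5F)ccc4=O)cc3)ccnc21` differs from compound 2 by methyl in place of hydrogen on an aromatic nitrogen. Going by the values given here, no measured step covers this change; the only step known, from compound 1 to compound 2, concerns a fluoro group elsewhere and does not bear on it. The expected step is therefore none beyond the scatter, a 1.1-fold higher number from compound 2 to compound 3 (0.06 log units; within the scatter). Compound 3 is estimated at 30000 nM, within 8000 nM to 110000 nM.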

Compound 3, half-maximal inhibitory concentration: 35700 nM
For compound 3 the middle estimate is 1.2-fold (0.08 log units) below the measured one; the measured number falls inside the stated range.
By their numbers in this assay, from the lowest: compound 1; then compounds 2 and 3 (each within the scatter of the next).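

In this assay, methyl in place of hydrogen on an aromatic nitrogen gives a 1.4-fold higher number from compound 2 to compound 3 (0.14 log units; within the scatter). So at this nitrogen of the five-membered aromatic ring, in the compound carrying the fluoro group, the swap from hydrogen to methyl moves the number no further than repeat measurements would. No measurement shown explains this outcome. Going by these compounds, whether an ethyl group, or a longer chain ending in an amine, would be tolerated on this nitrogen remains open. So does whether methyl would act the same way in compound 1, which lacks the fluoro group.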